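Moving a trifluoromethyl group on a benzyl ether

The source may report more compounds than this note shows. Statements on the series, on what has been measured and on what is new or still open speak of the compounds shown alone.

Compound 1 `Cc1ccc(NC(=S)NC(=O)c2ccc(OCc3cccc(Cl)c3)cc2)cc1-c1nc2ccccc2[nH]1` was tested in a functional assay on SW-620 cells (Homo sapiens) for inhibition, read by MTT assay, with a stated time of 48 h; on this read-out lower numbers stand for stronger inhibition and higher numbers for weaker inhibition. In this assay compound 1 reaches only a limit, > 100000 nM, which is the limit of > 100000 nM in this assay, at which 1 of the 2 values shown sits. Compound 2 `Cc1ccc(NC(=S)NC(=O)c2ccc(OCc3ccc(C(F)(F)F)cc3)cc2)cc1-c1nc2ccccc2[nH]1` carries a 4-(trifluoromethyl)phenyl in place of the 3-chlorophenyl of compound 1, and in this assay compound 2 gives 72400 nM. For the measured compounds named here, that step, an at least 1.3-fold lower number from compound 1 to compound 2 (0.14 log units; that floor lies within the scatter), is the only measured step, and compound 2 holds the only value that is a number rather than a limit. Compound 3 `Cc1ccc(NC(=S)NC(=O)c2ccc(OCc3cccc(C(F)(F)F)c3)cc2)cc1-c1nc2ccccc2[nH]1` is the next compound: 3-(trifluoromethyl)phenyl in place of 4-(trifluoromethyl)phenyl on a saturated chain carbon bound to an oxygen on an aromatic ring. The measured step changed both the group and its place on the ring, so it speaks only loosely to this change. Moving the trifluoromethyl to where the chloro of compound 1 stood may nudge the number toward that limit. The expected step is a 1.2-fold higher number from compound 2 to compound 3 (0.09 log units; within the scatter). Compound 3 is expected to give 90000 nM, within 45000 nM to 180000 nM.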

Compound 3, half-maximal inhibitory concentration: 15400 nM
Estimate against measurement, compound 3: 5.8-fold (0.77 log units) above; the measured number lies below the stated range.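

Replacing 4-(trifluoromethyl)phenyl with 3-(trifluoromethyl)phenyl keeps every atom and only joins them differently, yet this assay shows a 4.7-fold lower number from compound 2 to compound 3 (0.67 log units; beyond the scatter), so the place of the group matters here, which the earlier step could not show, as it changed group and place together. With the group in the place the chloro held, trifluoromethyl in place of chloro gives an at least 6.4-fold lower number from compound 1 to compound 3 (0.81 log units; beyond the scatter). That step is only a floor, since compound 1 stands at a limit and not at a number: the limit of > 100000 nM in this assay, at which 1 of the 3 values shown sits.

The compounds shown do not tell why the place of the trifluoromethyl counts, and no property of these groups is given as measured. From the compounds shown here alone, whether another group on the same ring, such as a nitrile or an amine, would keep the lower number also stays open.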